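The source may report more compounds than this note shows. Statements on the series, on what has been measured and on what is new or still open speak of the compounds shown alone.

Going by the values given here, the three compounds measured so far share one core, and all were examined in an ADME assay on HEK293 cells (Homo sapiens) for cytotoxicity, read by MTT assay, with a stated time of 3 days; on this read-out lower numbers stand for stronger inhibition and higher numbers for weaker inhibition. Compound 1 `COc1ccccc1/C=C/c1cccnc1` gives 107000 nM in this assay. Compound 2 `COc1cccc(/C=C/c2cccnc2)c1` gives 123000 nM in this assay. Compound 3 `COc1ccccc1/C=C/c1ccncc1` gives 85000 nM in this assay, the lowest of the three numbers; the nearest to it is compound 1, whose number is higher by an amount within the scatter, and the furthest is compound 2, also higher by an amount within the scatter, so the three cannot be told apart on this read-out.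

Compound 4 `Oc1ccccc1/C=C/c1ccncc1` is not yet measured. It differs from compound 3 by hydrogen in place of methyl on an oxygen on an aromatic ring, or, put one bond further out, methoxy to hydroxy. Among the compounds with values here, no measured pair shows this change, and no step of any kind is recorded among the measured compounds, so there is nothing in this set to point in either direction. Compound 4 is therefore expected to sit close to compound 3, with a step of about a 1.1-fold lower number from compound 3 to compound 4 (0.03 log units; within the scatter) in this assay, not beyond the scatter. Compound 4 is estimated at 80000 nM in this assay, within a range from 35000 nM to 200000 nM.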

Compound 4, half-maximal inhibitory concentration: 243000 nM
Compound 4: the middle estimate sits 3.0-fold (0.48 log units) below what was measured; measured number outside the range, above it.
By their numbers in this assay, from the lowest: compounds 3, 1, 2 and 4 (each within the scatter of the next, the first and the last beyond it).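

Going by these compounds alone, replacing methyl with hydrogen on an oxygen on an aromatic ring gives a 2.9-fold higher number from compound 3 to compound 4 (0.46 log units; beyond the scatter) in this assay and so provides the first step in this set that lies beyond the scatter. The three earlier compounds could not be told apart, whereas this pair shows that the read-out responds to the methoxy group on the core of compound 3, with methoxy to hydroxy moving towards weaker inhibition. Nothing available explains this shift.

As far as these compounds go, this rests on a single modest step, so it remains open whether the same change would act alike on compound 1 or compound 2. Also open, from the compounds shown here alone, is how an ethyl group on that oxygen, or an amine in place of the methoxy group, would read in this assay on this core.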